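Permeability Outlook for a Trifluoromethyl Analogue of Compound 3

This account rests on a few compounds, and the source may have more. Where it says the series, first, only, none or still open, it means among the compounds named here.

Of the compounds shown here, three built on a shared core have been measured. Compound 1 `COc1ccc(F)cc1CNCCCNc1ccnc2cc(CCc3ccccc3)ccc12`, compound 2 `Cc1cc(C)cc(Cc2ccc3c(NCCCNCc4ccco4)ccnc3c2)c1` and compound 3 `c1ccc(CCc2ccc3c(NCCCNCc4ccco4)ccnc3c2)cc1` each carry a three-carbon chain between two amine nitrogens, and they differ only at the two ends of the molecule. In an ADME assay for permeability, using PAMPA, with a stated time of 30 min, at pH 7.4 (on this read-out lower numbers stand for lower permeability and higher numbers for higher permeability), compound 1 gives 23 10^-6 cm/s, compound 2 gives 23 10^-6 cm/s and compound 3 gives 23 10^-6 cm/s. Compound 3 therefore stands level with both of its neighbours: the step of no change at the digits printed from compound 1 to compound 3 (within the scatter) and the step of no change at the digits printed from compound 2 to compound 3 (within the scatter) each fall within the scatter of this assay, so neither end of the molecule has yet moved the read-out.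

Compound 4 `FC(F)(F)c1cccc(Cc2ccc3c(NCCCNCc4ccco4)ccnc3c2)c1` is the next member of the series. It differs from compound 3 by 3-(trifluoromethyl)phenyl in place of benzyl on a saturated chain carbon bound to an aromatic carbon. The step that bears most directly on this change is no change at the digits printed from compound 2 to compound 3 (within the scatter), since it altered the group at the same saturated chain carbon bound to an aromatic carbon and produced no movement beyond the scatter. On that basis no step beyond the scatter is expected for compound 4 in this assay, and the expected step is no change at the digits printed from compound 3 to compound 4 (within the scatter). Compound 4 is estimated to give 23 10^-6 cm/s, with a range from 12 10^-6 cm/s to 40 10^-6 cm/s.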

Compound 4, apparent permeability: 23 10^-6 cm/s
The estimate for compound 4 equals the measured number at the digits printed, and the stated range covers the measured number.
By their numbers in this assay, from the lowest: compounds 1, 2, 3 and 4 (each within the scatter of the next).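

In this assay, among these compounds, the step to 3-(trifluoromethyl)phenyl on a saturated chain carbon bound to an aromatic carbon reads no change at the digits printed from compound 3 to compound 4 (within the scatter), and this is the first group at this place to contain fluorine, with 10 heavy atoms where benzyl has 7. Among the compounds shown here, the comparison with the other substituted ring at this place reads no change at the digits printed from compound 2 to compound 4 (within the scatter), so compounds 2, 3 and 4 now show three different groups at this carbon, and none of the steps among them goes beyond the scatter, with no compound among them going against that. The data give no measured property that would account for this flat result, and no explanation can be offered here.

All three groups at this place are free of hydrogen-bond donors and acceptors and carry no net charge, so the compounds shown leave open whether an amine or a carboxylic acid on the same ring would shift the read-out. They also leave open whether a longer chain in place of the one joining the two amine nitrogens would leave these values within the scatter.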